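Isoxazole attachment shift on an imidazoline aniline scaffold

The source may report more compounds than this note shows. Statements on the series, on what has been measured and on what is new or still open speak of the compounds shown alone.

Compound 1, `c1coc(-c2ccccc2NCC2=NCCN2)c1`: 16.2 nM
Compound 2, `c1csc(-c2ccccc2NCC2=NCCN2)c1`: 18.2 nM
Compound 3, `Cc1cc(-c2ccccc2NCC2=NCCN2)on1`: < 100000 nM

In a functional assay for activation of Alpha-1D adrenergic receptor (Homo sapiens) (a lower number here means that less compound is needed, a higher number that more compound is needed for the effect), compound 1 gives 16.2 nM and compound 2 gives 18.2 nM, with a 1.1-fold higher number from compound 1 to compound 2 (0.05 log units; within the scatter). For compound 3 the assay reports only a limit, < 100000 nM. The steps a step that the limit leaves unreadable from compound 1 to compound 3 and a step that the limit leaves unreadable from compound 2 to compound 3 cannot be sized. Compound 3 stands apart from the other two only as a limit, not as a number.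

Compound 4, `c1ccc(-c2cnoc2)c(NCC2=NCCN2)c1`, differs from compound 3 by 1,2-oxazol-4-yl in place of 3-methyl-1,2-oxazol-5-yl on an aromatic carbon. Among the measured compounds shown here, no measured step bears directly on this exchange, since both steps reaching compound 3 end at a limit. Compound 4 is therefore estimated at 2000 nM, between 60 nM and 60000 nM, which would mean an expected step that the limit leaves unreadable from compound 3 to compound 4.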

Compound 4, half-maximal effective concentration: < 100000 nM
Compound 4: no number, only a limit; the forecaster's own chance of this, stated with the estimate: 30%; the middle value lies beyond the limit too.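

In this assay, among the compounds shown here, compound 4 gives < 100000 nM as a limit and not a number, and no step linking it to compound 1, compound 2 or compound 3 can be read. The compounds shown leave open how far compound 3 and compound 4 lie from compound 1 and compound 2, and whether compound 3 and compound 4 differ from each other.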